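The compounds below may be only part of what the source reports. "The series", "measured", "known", "first", "only" and "open" are said of these compounds alone.

Compound 1 `CCCCCCCCCCCCCCCCOP(=O)(O)OCCSC(=S)N1CCCCC1` is the starting point of this account. In a functional assay on MDA-MB-231 cells (Homo sapiens) for inhibition, read by MTT assay, with stated times of 18 h and 4 h (on this read-out lower numbers stand for stronger inhibition and higher numbers for weaker inhibition), compound 1 gives 100000 nM, the highest of the three numbers recorded so far. Compound 2 `CCCCCCCCCCOP(=O)(O)OCCSC(=S)N1CCCC1` gives 67000 nM in this assay, a value that lies within the scatter of compound 1. Compound 3 `CCCCCCCCOP(=O)(O)OCCSC(=S)N1CCCCCC1` gives 27000 nM in this assay, a number beyond the scatter of compound 1 and lower than it. Compound 4 `CCCCCCOP(=O)(O)OCCSC(=S)N1CCCCC1` is not yet measured. It differs from compound 1 by hydrogen in place of decyl on a saturated chain carbon, six bonds along the chain from an oxygen on an unsaturated carbon. Among the compounds with values here, no measured pair with the same change exists, so the expectation rests on the spread of the three values alone: the step of a 1.8-fold lower number from compound 1 to compound 4 (0.26 log units; within the scatter) is expected to be modest, toward a lower number, and not far beyond the scatter. Compound 4 is estimated at 55000 nM, within a range from 20000 nM to 150000 nM.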

Compound 4, half-maximal inhibitory concentration: 85000 nM
For compound 4 the middle estimate is 1.5-fold (0.19 log units) below the measured one; low and high end bracket the measured number.
By their numbers in this assay, from the lowest: compound 3; then compounds 2, 4 and 1 (each within the scatter of the next).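

Within the data shown here, the first comparison in one place shows that hydrogen in place of decyl on this saturated chain carbon gives a 1.2-fold lower number from compound 1 to compound 4 (0.07 log units; within the scatter) in this assay, so this change does not separate compound 4 from compound 1 on this read-out. No measurement at hand offers an explanation for this result. From the compounds shown here alone, whether an amine or a carboxylic acid in place of decyl at this position would give a step beyond the scatter remains open. So does the effect of changing the ring alone while the chain stays the same.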